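This account rests on a few compounds, and the source may have more. Where it says the series, first, only, none or still open, it means among the compounds named here.

Measured compounds:
compound 1, `COc1ccc(C(=O)/C=C/c2cc(OC)c(OC)c(OC)c2)c2c1C=CC(C)(C)O2`, 9150 nM
compound 2, `COc1ccc(C(=O)/C=C/c2ccc(F)cc2)c2c1C=CC(C)(C)O2`, > 10000 nM

In a functional assay on SW-620 cells (Homo sapiens) for antiproliferative activity, read by MTT assay, with a stated time of 24 h (on this read-out lower numbers stand for stronger inhibition and higher numbers for weaker inhibition), compound 1 gives 9150 nM. For compound 2 only a limit is reported, > 10000 nM, which is the limit of > 10000 nM in this assay, at which 1 of the 2 values shown sits, so no number stands for it. Compound 3, `COc1ccc(C(=O)/C=C/c2ccc(N3CCCC3)cc2)c2c1C=CC(C)(C)O2`, differs from compound 2 by pyrrolidin-1-yl in place of fluoro on an aromatic carbon. Going by the values given here, no measured pair covers this change, so nothing tells the size of the step; the whole series sits at weak inhibition. Compound 3 is expected at 6000 nM, within 1500 nM to 20000 nM. The expected step of an at least 1.6-fold lower number from compound 2 to compound 3 (0.22 log units; that floor lies within the scatter) would be a modest gain, possibly no more than the scatter.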

Compound 3, half-maximal inhibitory concentration: 7150 nM
Compound 3: the middle estimate sits 1.2-fold (0.08 log units) below what was measured; the range from low to high includes it.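

With pyrrolidin-1-yl in place of fluoro on an aromatic carbon, para to a large group, this position now has its first readable step in this assay: an at least 1.3-fold lower number from compound 2 to compound 3 (0.14 log units; that floor lies within the scatter). Compound 3 gives a number, 7150 nM, so a pyrrolidin-1-yl group at this position keeps inhibition within the measurable range. Compound 2 remains a limit and not a number, so the step has a floor but no upper size: the limit of > 10000 nM in this assay, at which 1 of the 3 values shown sits.

Going by these compounds, whether this change does more than the scatter stays open. On these data alone, how a dimethylamino group, a morpholin-4-yl group or a carboxylic acid would read at this position also stays open.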